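Chloro to Hydrogen on an Aromatic Carbon, Seen Twice

This account rests on a few compounds, and the source may have more. Where it says the series, first, only, none or still open, it means among the compounds named here.

Measured compounds:
Compound 1, `Oc1ccc(O)c(COCc2cc(O)cc(Cl)c2O)c1`, 4300 nM
Compound 2, `Oc1ccc(O)c(COCc2cc(O)ccc2O)c1`, 4600 nM
Compound 3, `OCc1cc(OCc2cc(O)ccc2O)cc(Cl)c1O`, 4400 nM

In a functional assay (a higher number here means a weaker inhibitor, a lower number a stronger inhibitor), compound 3 gives 4400 nM. On the three numbers at hand it sits in the middle, but its values to compound 1 and compound 2 both lie within the scatter, so no order among the three can be drawn.

Compound 4, `OCc1cc(OCc2cc(O)ccc2O)ccc1O`, has not yet been measured. It differs from compound 3 in one place: hydrogen in place of chloro on an aromatic carbon.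

The same kind of change has been measured once already, from compound 1 to compound 2: a 1.1-fold higher number from compound 1 to compound 2 (0.03 log units; within the scatter). That step was within the scatter. Going by the values given here, with only this one precedent, and it flat, no step beyond the scatter is expected from compound 3 to compound 4 in this assay.

Accordingly compound 4 is estimated at 4700 nM, in the range 2400 nM to 9400 nM. The step this estimate implies, a 1.1-fold higher number from compound 3 to compound 4 (0.03 log units; within the scatter), is expected to stay within the scatter.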

Compound 4, half-maximal inhibitory concentration: 6200 nM
Beside the measured number, compound 4's estimate is 1.3-fold (0.12 log units) below it, and the stated range covers the measured number.
By their numbers in this assay, from the lowest: compounds 1, 3, 2 and 4 (each within the scatter of the next).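

In this assay, hydrogen in place of chloro on an aromatic carbon, ortho to a hydroxy group, gives a 1.4-fold higher number from compound 3 to compound 4 (0.15 log units; within the scatter), so on this second core too the step does not leave the scatter. The earlier compounds shown here showed this change only once; it has now been read on two cores, and the two readings agree: the same change on two cores in this assay, a 1.1-fold higher number (0.03 log units; within the scatter) from compound 1 to compound 2 and a 1.4-fold higher number (0.15 log units; within the scatter) from compound 3 to compound 4, 1.3-fold (0.12 log units) apart, within the scatter of two such steps. For these two pairs, then, chloro and hydrogen at this position cannot be told apart in this assay.

The compounds shown carry only chloro or hydrogen here, so it remains open whether a methoxy group, an amine or a carboxylic acid at this position would give a step beyond the scatter. Also open, as far as these compounds go, is what a longer chain in place of the hydroxymethyl group would do.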